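A few compounds are considered here, and "the series" means these few. Any claim that something is new, unique, unknown or untested is made for them only; others in the source may bear on it.

Compound 3, whose structure is `CC(C)c1ccc(-n2nncc2-c2cn([C@H]3C[C@H](O)[C@@H](CO)O3)c(=O)[nH]c2=O)cc1`, is one of three compounds with numbers in an ADME assay on L1210 cells (Mus musculus) for cytotoxicity, read by cell counting, with a stated time of 2 days; on this read-out higher numbers stand for weaker inhibition and lower numbers for stronger inhibition. Compound 1, with the structure `CCCCc1ccc(-n2cc(-c3cn([C@H]4C[C@H](O)[C@@H](CO)O4)c(=O)[nH]c3=O)nn2)cc1`, gives 15000 nM in this assay. Compound 2, with the structure `O=c1[nH]c(=O)n([C@H]2C[C@H](O)[C@@H](CO)O2)cc1-c1cnnn1-c1c(F)cccc1F`, gives 10000 nM in this assay. For compound 3 the value in this assay is a limit rather than a number, > 200000 nM, so compound 3 stands at the weak end of what has been measured, at the limit of > 200000 nM in this assay, at which 1 of the 3 values shown sits. The only step recorded among these compounds runs an at least 20-fold higher number from compound 2 to compound 3 (1.30 log units; beyond the scatter).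

Compound 4, with the structure `O=c1[nH]c(=O)n([C@H]2C[C@H](O)[C@@H](CO)O2)cc1-c1cnnn1-c1ccc(Br)cc1`, is not yet measured. It differs from compound 3 by bromo in place of isopropyl on an aromatic carbon. Among the measured compounds shown here, the step that bears on this change is the one from compound 2 to compound 3, which was large, but it changed the whole aryl group and not only the group on the aromatic carbon, so it speaks only indirectly to the exchange of isopropyl for bromo. Compound 4 is therefore expected to move back toward the numbers of compound 1 and compound 2, by a step of an at least 4.0-fold lower number from compound 3 to compound 4 (0.60 log units; beyond the scatter) in this assay. The estimate for compound 4 in this assay is 50000 nM, in a range from 10000 nM to 250000 nM, with a real chance that only a limit is returned again.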

Compound 4, half-maximal inhibitory concentration: 61000 nM
Compound 4: the middle estimate sits 1.2-fold (0.09 log units) below what was measured; low and high end bracket the measured number.
By their numbers in this assay, from the lowest: compounds 2 and 1 (each within the scatter of the next); then compound 4. At a limit, above all of these: compound 3.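

In this assay, the exchange of isopropyl for bromo on this aromatic carbon, para to a large group, is the only step shown that alters this group alone, and it gives an at least 3.2-fold lower number from compound 3 to compound 4 (0.51 log units; beyond the scatter), so this single position moves the number beyond the scatter. The 4-bromophenyl group still does not match the 2,6-difluorophenyl group, with a 6.1-fold higher number from compound 2 to compound 4 (0.79 log units; beyond the scatter), which means that the large rise seen with the 4-isopropylphenyl group is only partly reversed by replacing isopropyl with bromo. Compound 3 gives only a limit, so the true size of its step to compound 4 remains unknown: the limit of > 200000 nM in this assay, at which 1 of the 4 values shown sits.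

On these data alone, whether an amine, a carboxylic acid or a longer chain on this carbon would bring the number closer to that of compound 2 remains open, as does whether a single fluoro on the phenyl ring would do so. Compound 1 differs from the other compounds in more than one place, so it leaves open how its butyl group compares with isopropyl or bromo at this position.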